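Phenyl in Place of 2-Fluorobenzyl on a Ring Amine

The source may hold more compounds than are shown below. What is called first, only, known or untested is meant among the compounds shown, and "the series" means these compounds.

Compound 1 `CC(C)Oc1nc(N)nc2ncc(-c3ccc(C#N)cc3)nc12` — > 10000 nM
Compound 2 `COc1ccc(-c2cnc3nc(N)nc(N4CCN(Cc5ccccc5F)CC4)c3n2)cc1OC` — 700 nM
Compound 3 `CCOc1nc(N)nc2ncc(-c3ccc(F)c(F)c3)nc12` — > 10000 nM

Of the compounds shown here, three with a shared core have been tested in a functional assay on cells (T-cell, Homo sapiens) for inhibition; a higher number here means a weaker inhibitor, a lower number a stronger inhibitor. For compound 1 the value > 10000 nM is a limit of the assay and not a number. For compound 3 the value > 10000 nM is likewise a limit. In this assay, among the compounds with values here, compound 2 gives 700 nM, the only number among the three, so compound 2 stands alone as the one with a measured inhibitory concentration, while the other two are known only to be weaker than the assay can resolve.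

Compound 4 `COc1ccc(-c2cnc3nc(N)nc(N4CCN(c5ccccc5)CC4)c3n2)cc1OC` is still to be measured. It differs from compound 2 in one place: phenyl in place of 2-fluorobenzyl on an amine nitrogen in a ring. Within the data shown here, no pair of measured compounds differing in a single place is available, so the size of this step cannot be read from earlier data. A modest weakening, near the edge of the usual scatter, is expected, giving a 2.1-fold higher number from compound 2 to compound 4 (0.33 log units; beyond the scatter). Compound 4 is therefore estimated at 1500 nM, with a range from 300 nM to 8000 nM.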

Compound 4, half-maximal inhibitory concentration: 400 nM
The estimate for compound 4 lay 3.8-fold (0.57 log units) above the measured number; low and high end bracket the measured number.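

Putting phenyl in place of 2-fluorobenzyl on this amine nitrogen in a ring gives, in this assay, a 1.8-fold lower number from compound 2 to compound 4 (0.24 log units; within the scatter), so the two groups cannot be told apart here. Within the data shown here, this is the first comparison in the set that changes a single place, and it shows that this position accepts either group with the inhibition still measurable. Nothing measured here offers a reason why the two groups read alike.

As far as these compounds go, it remains open whether an aromatic ring is needed on this nitrogen at all, or whether a small group such as methyl, or a longer chain ending in an amine, would read the same way. Also open, from the compounds shown here alone, is whether a carboxylic acid on the phenyl ring of compound 4 would shift the number.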